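This account rests on a few compounds, and the source may have more. Where it says the series, first, only, none or still open, it means among the compounds named here.

Compounds measured so far:
- compound 1 `COc1cc2c(Nc3ccc(C#N)cc3)ncnc2cc1OCCCN1CCCCC1`, which in a functional assay on A549 cells (Homo sapiens) for antiproliferative activity, read by MTT assay, with a stated time of 72 h (a lower number here means a stronger inhibitor, a higher number a weaker inhibitor), gives 23500 nM.
- compound 2 `COc1cc2c(Nc3ccc(C#N)cc3)ncnc2cc1OCCCN1CCC(CO)CC1`, for which this assay reports only a limit, > 100000 nM.
- compound 3 `COc1cc2c(Nc3ccc(C#N)cc3)ncnc2cc1OCCCN1CCCCC1CCO`, for which this assay likewise reports only a limit, > 100000 nM.

Compound 3 thus stands at the edge of what this assay can read: its value is a limit, not a number, and it shares this with compound 2 (the limit of > 100000 nM in this assay, at which 2 of the 3 values shown sit). Compound 4 `COc1cc2c(Nc3ccc(C#N)cc3)ncnc2cc1OCCCN1CCc2ccccc2C1` differs from it in one place: 1,2,3,4-tetrahydroisoquinolin-2-yl in place of 2-(2-hydroxyethyl)piperidin-1-yl on a saturated chain carbon, three bonds along the chain from an oxygen on an aromatic ring. For the measured compounds named here, two measured steps bear on this. Moving from the bare piperidine of compound 1 to its hydroxylated relatives gave an at least 4.2-fold higher number from compound 1 to compound 2 (0.62 log units; beyond the scatter) and an at least 4.2-fold higher number from compound 1 to compound 3 (0.62 log units; beyond the scatter), while the step between the two hydroxylated compounds is a step that the two limits leave unreadable from compound 2 to compound 3. The change to compound 4 removes the hydroxyl-bearing group altogether and brings in a ring-fused amine carrying no hydroxyl, which puts compound 4 closer in kind to compound 1 than to compound 3. Compound 4 is therefore expected to come back inside the readable range, a step estimated as an at least 5.0-fold lower number from compound 3 to compound 4 (0.69 log units; beyond the scatter). On that basis compound 4 is estimated at 20000 nM, within a range of 5000 nM to 90000 nM.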

Compound 4, half-maximal inhibitory concentration: > 100000 nM
Compound 4 was reported as a limit (the forecaster's own chance of this, stated with the estimate: 25%); middle value at least 5.0-fold (0.69 log units) away from the limit.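

Compound 4 carries no hydroxyl, yet in this assay compound 4 gives > 100000 nM, which is a limit and not a number. The loss of a readable value at this chain carbon is therefore not confined to the hydroxyl-bearing piperidines: replacing piperidin-1-yl with 1,2,3,4-tetrahydroisoquinolin-2-yl, a group with an added aromatic ring and no hydrogen-bond donor, gives an at least 4.2-fold higher number from compound 1 to compound 4 (0.62 log units; beyond the scatter). The steps among compound 2, compound 3 and compound 4 cannot be read, and of the amines shown only the unsubstituted piperidine of compound 1 gives a number, with the others sitting at one edge of the assay: the limit of > 100000 nM in this assay, at which 3 of the 4 values shown sit.

Going by these compounds, the true values of compound 2, compound 3 and compound 4 remain unknown, so these three cannot be put in any order, and it is not possible to say whether one of the changes costs more than another. On these data alone, it also remains open whether the unsubstituted piperidine is unusual at this position, or whether a morpholin-4-yl, a pyrrolidin-1-yl or a dimethylamino group on the same chain would also give a readable value.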